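The compounds below may be only part of what the source reports. "The series", "measured", "known", "first", "only" and "open" are said of these compounds alone.

Compound 1 `CN(C)C(=O)c1cc(-c2cnc(NCc3c(F)ccc4c3CCO4)c3cn[nH]c(=O)c23)n(C)n1`: 21 mL.min-1.g-1
Compound 2 `Cc1cc(-c2cnc(NCc3c(F)ccc4c3CCO4)c3cn[nH]c(=O)c23)n(C)n1`: 24 mL.min-1.g-1
Compound 3 `CNC(=O)c1cc(-c2cnc(NCc3c(F)ccc4c3CCO4)c3cn[nH]c(=O)c23)n(C)n1`: < 3 mL.min-1.g-1, which is a limit of the assay rather than a number.

All three were tested in an ADME assay on microsomes from liver (Homo sapiens) for metabolic stability, read by LC-MS, using NADPH, with stated times of 5 min and 30 min, tested at 1 uM; on this read-out lower numbers stand for slow clearance and higher numbers for fast clearance. Compound 3 sits at the limit of the limit of < 3 mL.min-1.g-1 in this assay, at which 1 of the 3 values shown sits, so its clearance is known only as a bound. The steps of an at least 7.0-fold lower number from compound 1 to compound 3 (0.84 log units; beyond the scatter) and an at least 8.0-fold lower number from compound 2 to compound 3 (0.90 log units; beyond the scatter) both end at that bound. Compound 4 `O=C1CCCN1c1cnc(NCc2c(F)ccc3c2CCO3)c2cn[nH]c(=O)c12` differs from compound 3 by 2-oxopyrrolidin-1-yl in place of 1-methyl-3-(methylcarbamoyl)-1H-pyrazol-5-yl on an aromatic carbon. For the measured compounds named here, no measured step swaps this whole group, so none bears on it directly; the two steps ending at compound 3 show only that changes at this position moved the number beyond the scatter. Compound 4 is therefore expected to move up from the limit by an at least 2.6-fold higher number from compound 3 to compound 4 (0.42 log units; beyond the scatter), with an estimate of 8 mL.min-1.g-1 and a range from 3 mL.min-1.g-1 to 25 mL.min-1.g-1.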

Compound 4, intrinsic clearance in microsomes: 23 mL.min-1.g-1
For compound 4 the middle estimate is 2.9-fold (0.46 log units) below the measured one; the measured number falls inside the stated range.
By their numbers in this assay, from the lowest: compounds 1, 4 and 2 (each within the scatter of the next). At a limit, below all of these: compound 3.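

The step of an at least 7.6-fold higher number from compound 3 to compound 4 (0.88 log units; beyond the scatter) starts from compound 3, whose value is a limit and not a number. The steps of a 1.0-fold lower number from compound 2 to compound 4 (0.02 log units; within the scatter) and a 1.1-fold higher number from compound 1 to compound 4 (0.04 log units; within the scatter) both lie within the scatter, so 2-oxopyrrolidin-1-yl, with no aromatic ring, reads level with two of the pyrazole groups at this position. Among these four compounds, only 1-methyl-3-(methylcarbamoyl)-1H-pyrazol-5-yl gives the low clearance reading.

As far as these compounds go, it remains open whether that reading needs the pyrazole ring or only the methylcarbamoyl group. A methylcarbamoyl group on the 2-oxopyrrolidin-1-yl ring, or an unsubstituted carboxamide on the pyrazole, would help separate the two.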